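Two cores, one chlorophenyl swap: working notes

A few compounds are considered here, and "the series" means these few. Any claim that something is new, unique, unknown or untested is made for them only; others in the source may bear on it.

Measured so far in a functional assay on MDA-MB-231 cells (Homo sapiens) for cytotoxicity, read by MTT assay, with a stated time of 24 h; on this read-out higher numbers stand for weaker inhibition and lower numbers for stronger inhibition:
- compound 1 `O=C1/C(=C/c2ccccc2F)CN(Cc2cn(Cc3cccc(Cl)c3)nn2)C/C1=C\c1ccccc1F` gives 12000 nM
- compound 2 `COc1ccc(/C=C2\CN(C(=S)SCc3cn(Cc4cccc(Cl)c4)nn3)C/C(=C\c3ccc(OC)cc3)C2=O)cc1` gives 32000 nM
- compound 3 `O=C1/C(=C/c2ccccc2F)CN(Cc2cn(Cc3ccccc3Cl)nn2)C/C1=C\c1ccccc1F` gives 16500 nM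

The change 2-chlorophenyl in place of 3-chlorophenyl on a saturated chain carbon bound to an aromatic nitrogen gives a 1.4-fold higher number from compound 1 to compound 3 (0.14 log units; within the scatter) in this assay. Compound 2 carries a different core; the difference between the two cores is not broken down here. Its value lies beyond the scatter from compound 1, while against compound 3 the two values lie within the scatter of each other.

Compound 4 `COc1ccc(/C=C2\CN(C(=S)SCc3cn(Cc4ccccc4Cl)nn3)C/C(=C\c3ccc(OC)cc3)C2=O)cc1` is not yet measured. It carries 2-chlorophenyl in place of 3-chlorophenyl on a saturated chain carbon bound to an aromatic nitrogen, the same change as from compound 1 to compound 3. Going by the values given here, the step from compound 2 to compound 4 is expected to be a 1.3-fold higher number from compound 2 to compound 4 (0.10 log units; within the scatter), resting on the single earlier step of a 1.4-fold higher number from compound 1 to compound 3 (0.14 log units; within the scatter), which is within the scatter. Compound 4 is therefore estimated at 40000 nM, between 18000 nM and 90000 nM.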

Compound 4, half-maximal inhibitory concentration: > 100000 nM
Compound 4 gave a limit, no number; the forecaster's own chance of this, stated with the estimate: 15%; middle value at least 2.5-fold (0.39 log units) away from the limit.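

On the core of compound 2, 2-chlorophenyl in place of 3-chlorophenyl gives an at least 3.1-fold higher number from compound 2 to compound 4 (0.49 log units; beyond the scatter) in this assay. As far as these compounds go, compound 4 reads > 100000 nM, which is a limit of the assay and not a number, so the full size of this step stays unknown. The step is beyond the scatter on this core, but the comparison with the other core does not show that the change carries over differently: the same change on two cores in this assay, a 1.4-fold higher number (0.14 log units; within the scatter) from compound 1 to compound 3 and an at least 3.1-fold higher number (0.49 log units; beyond the scatter) from compound 2 to compound 4; the limit leaves it open whether they differ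

The compounds shown leave open how either core responds when an unsubstituted benzyl or a benzyl bearing a carboxylic acid takes the place of the chlorobenzyl group. From the compounds shown here alone, a measurable value for a 2-chlorobenzyl compound on the core of compound 2 also remains open.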